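A few compounds are considered here, and "the series" means these few. Any claim that something is new, unique, unknown or untested is made for them only; others in the source may bear on it.

Measured so far, in a functional assay on MCF7 cells (Homo sapiens) for antiproliferative activity, read by MTT assay, with a stated time of 48 h; on this read-out lower numbers stand for stronger inhibition and higher numbers for weaker inhibition:

Compound 1, `FC(F)(F)c1ccc2[nH]c(-c3cn(-c4ccccc4)nc3-c3ccc(Cl)cc3)nc2c1`: 4210 nM
Compound 2, `Cc1ccc2[nH]c(-c3cn(-c4ccccc4)nc3-c3ccc(Cl)cc3)nc2c1`: 8230 nM
Compound 3, `COc1ccc(-c2nn(-c3ccccc3)cc2-c2nc3cc(C(F)(F)F)ccc3[nH]2)cc1`: 5730 nM

Compound 4, `COc1ccc(-c2nn(-c3ccccc3)cc2-c2nc3cc(C)ccc3[nH]2)cc1`, has not yet been measured.

Compound 2 is made from compound 1 by one change, (methyl in place of trifluoromethyl on an aromatic carbon), and the result was a 2.0-fold higher number from compound 1 to compound 2 (0.29 log units; within the scatter). Compound 4 is made from compound 3 by the same change, (methyl in place of trifluoromethyl on an aromatic carbon), with the place of the change described in the same words. The two cores on which it is made differ elsewhere: methoxy in place of chloro on an aromatic carbon, and between those two cores the step was a 1.4-fold higher number from compound 1 to compound 3 (0.13 log units; within the scatter).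

Because the step of a 2.0-fold higher number from compound 1 to compound 2 (0.29 log units; within the scatter) was small and within the scatter, the step from compound 3 to compound 4 is expected to be of the same modest size, roughly a 1.7-fold higher number from compound 3 to compound 4 (0.24 log units; within the scatter). That expectation rests only on this one earlier pair and on the value of compound 3, 5730 nM.

Compound 4 is therefore estimated at about 10000 nM in this assay, with a plausible range from 4000 nM to 25000 nM.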

Compound 4, half-maximal inhibitory concentration: 6610 nM
The estimate for compound 4 lay 1.5-fold (0.18 log units) above the measured number, within the range that was stated.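

In this assay, putting methyl in place of trifluoromethyl on the core carrying methoxy gave a 1.2-fold higher number from compound 3 to compound 4 (0.06 log units; within the scatter), a step that agrees with the one seen on the core carrying chloro: the same change on two cores in this assay, a 2.0-fold higher number (0.29 log units; within the scatter) from compound 1 to compound 2 and a 1.2-fold higher number (0.06 log units; within the scatter) from compound 3 to compound 4, 1.7-fold (0.23 log units) apart, within the scatter of two such steps. Read the other way, methoxy in place of chloro on the core carrying methyl gave a 1.2-fold lower number from compound 2 to compound 4 (0.10 log units; within the scatter), and this also agrees with the earlier step for that change: the same change on two cores in this assay, a 1.4-fold higher number (0.13 log units; within the scatter) from compound 1 to compound 3 and a 1.2-fold lower number (0.10 log units; within the scatter) from compound 2 to compound 4, 1.7-fold (0.23 log units) apart, within the scatter of two such steps. Each change therefore carried from one core to the other without a detectable difference, but every step here is within the scatter, so this does not show that either change truly shifts the number on any core, and two cores cannot set a rule for the whole series.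

The compounds shown leave open whether another group at the place of the trifluoromethyl, such as an amine or a carboxylic acid, would give a step beyond the scatter. They also leave open whether these changes would behave alike on cores that differ elsewhere.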